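A few compounds are considered here, and "the series" means these few. Any claim that something is new, unique, unknown or untested is made for them only; others in the source may bear on it.

Compound 1 `CNS(=O)(=O)c1ccc2c(c1)C(n1ccccc1=O)=CC(C)(C)O2` gives 85.8% in a functional assay on the whole organism (aorta) with Rattus norvegicus as the target; on this read-out lower numbers stand for smaller maximal responses and higher numbers for larger maximal responses. Compound 2 `CCNS(=O)(=O)c1ccc2c(c1)C(n1ccccc1=O)=CC(C)(C)O2` gives 72.4% in this assay, and compound 3 `CN(C)S(=O)(=O)c1ccc2c(c1)C(n1ccccc1=O)=CC(C)(C)O2` gives 78.3%. Compound 3 thus sits between the other two, but both gaps lie within the scatter: a number 5.9 percentage points higher from compound 2 to compound 3 (within the scatter) and a number 7.5 percentage points lower from compound 1 to compound 3 (within the scatter), so no ordering among the three can be claimed. For the measured compounds named here, the only step beyond the scatter is a number 13.4 percentage points lower from compound 1 to compound 2 (beyond the scatter).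

Compound 4 `CC1(C)C=C(n2ccccc2=O)c2cc(S(=O)(=O)Oc3ccccc3)ccc2O1` has not been measured in this assay. It differs from compound 3 in one place: phenoxy in place of dimethylamino on a sulfonyl sulfur. All three measured steps touch the same sulfonyl group, so they bear on this change, yet each swaps only small alkyl pieces on the sulfonamide nitrogen, and none removes that nitrogen for an oxygen-linked aromatic ring. The largest of them, a number 13.4 percentage points lower from compound 1 to compound 2 (beyond the scatter), was modest; the others were within the scatter. Because a number 13.4 percentage points lower from compound 1 to compound 2 (beyond the scatter) shows that adding carbon at this position can lower the response, compound 4 is expected to give a somewhat lower value, with wide uncertainty, estimated as a number 12.3 percentage points lower from compound 3 to compound 4 (beyond the scatter). Compound 4 is therefore estimated at 66%, within the range 45% to 85%.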

Compound 4, largest response reached (Emax), in percent of the reference or control that the assay uses: 67.9%
For compound 4 the middle estimate is 1.9 percentage points below the measured one; the measured number falls inside the stated range.
By their numbers in this assay, from the lowest: compounds 4, 2, 3 and 1 (each within the scatter of the next, the first and the last beyond it).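

In this assay, phenoxy in place of dimethylamino on a sulfonyl sulfur gives a modest change (a number 10.4 percentage points lower from compound 3 to compound 4 (beyond the scatter)), and the same holds for phenoxy in place of methylamino (a number 17.9 percentage points lower from compound 1 to compound 4 (beyond the scatter)). A maximal response of similar order therefore survives when the sulfonamide nitrogen is gone and an oxygen-linked aromatic ring takes its place, which the alkyl swaps could not show. Set against the ethylamino group, phenoxy gives no step that can be told from scatter (a number 4.5 percentage points lower from compound 2 to compound 4 (within the scatter)), so compound 4 and compound 2 cannot be ordered. Nothing given here accounts for these steps.

From the compounds shown here alone, whether the lower numbers follow the oxygen link or the aromatic ring stays open. A methoxy group or an anilino group on the sulfonyl sulfur would separate the two, and a chlorine on the phenoxy ring would test the ring itself.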